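Removing One Methyl from Compound 1

The compounds below may be only part of what the source reports. "The series", "measured", "known", "first", "only" and "open" are said of these compounds alone.

Measured so far in a functional assay on MCF7 cells (Homo sapiens) for cytotoxicity, read by MTT assay; a higher number here means a weaker inhibitor, a lower number a stronger inhibitor:

- compound 1 `CCOC(=O)C(C)Oc1cc(O)c2c(=O)c(O)c(-c3ccc(OC)cc3)oc2c1CC=C(C)C`: > 100000 nM
- compound 2 `COc1ccc(-c2oc3c(CC=C(C)C)c(OCCO)cc(O)c3c(=O)c2OCCO)cc1`: > 100000 nM
- compound 3 `COc1ccc(-c2oc3c(CC=C(C)C)c(OCCCC(=O)O)cc(O)c3c(=O)c2OCCCC(=O)O)cc1`: > 100000 nM

Compound 1 gives only a limit, > 100000 nM, and not an exact number. It is not alone in this, as compound 2 and compound 3 also stop at a limit. The whole set comes down to the limit of > 100000 nM in this assay, at which 3 of the 3 values shown sit. Going by the values given here, nothing measured so far therefore ranks these compounds against one another.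

Compound 4 `CCOC(=O)COc1cc(O)c2c(=O)c(O)c(-c3ccc(OC)cc3)oc2c1CC=C(C)C` is the next one to be tested. It differs from compound 1 in one place: hydrogen in place of methyl on a saturated chain carbon bound to a carbonyl carbon and an oxygen on an aromatic ring. In words, this is hydrogen in place of methyl on a saturated chain carbon bound to a carbonyl carbon and an oxygen on an aromatic ring, so 1-(ethoxycarbonyl)ethoxy becomes (ethoxycarbonyl)methoxy.

Among the compounds with values here, no two measured compounds differ in just one place, so the data give no direct measure of what such a change does. The expectation rests on compound 1 and its limit of > 100000 nM. The expected result in this assay is no change beyond the usual scatter, and another limit is the most likely reading. The estimated size of the change is a number no higher from compound 1 to compound 4 (the limit leaves the size open). Compound 4 is estimated at 100000 nM, with an expected range from 40000 nM to 200000 nM.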

Compound 4, half-maximal inhibitory concentration: 27900 nM
Compound 4: the middle estimate sits 3.6-fold (0.55 log units) above what was measured, outside the stated range (below it).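

At the saturated chain carbon bound to a carbonyl carbon and an oxygen on an aromatic ring, a single small change proves able to move the read-out: in this assay, hydrogen in place of methyl gives an at least 3.5-fold lower number from compound 1 to compound 4 (0.55 log units; beyond the scatter). The earlier compounds shown here could not show this, as none of them gave an exact number and no two of them differed in just one place, whereas (ethoxycarbonyl)methoxy in compound 4 now gives a measured value, while 1-(ethoxycarbonyl)ethoxy in compound 1 stays at a limit. The step therefore has a known minimum but no known full size, and most of this set offers no exact number to compare with compound 4: the limit of > 100000 nM in this assay, at which 3 of the 4 values shown sit.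

Going by these compounds, it remains open whether an ethyl group on this same chain carbon would return the number to the limit, or whether a fluorine there would behave more like hydrogen or like methyl. Also open, on these data alone, is how far the ethyl ester of compound 4 matters, which an amide or a free carboxylic acid at that end of the same short chain could show.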